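A few compounds are considered here, and "the series" means these few. Any claim that something is new, unique, unknown or untested is made for them only; others in the source may bear on it.

Of the compounds shown here, three that share one core have been tested in a functional assay on HEK293 cells (Homo sapiens) for cytotoxicity; a higher number here means that more compound is tolerated, a lower number that less compound is tolerated. They differ in the group on the amide-type nitrogen: compound 1 (`COc1ccc([C@H]2CC(=O)N(Cc3cccc(N)c3)C2)cc1OC1CCCC1`) carries 3-aminobenzyl, compound 2 (`COc1ccc([C@H]2CC(=O)N(c3ccc(C#N)cc3)C2)cc1OC1CCCC1`) carries 4-cyanophenyl and compound 3 (`COc1ccc([C@H]2CC(=O)N(c3ccc(C(F)(F)F)cc3)C2)cc1OC1CCCC1`) carries 4-(trifluoromethyl)phenyl. Compound 1 gives > 10000 nM as a limit of the assay, not a number. Compound 2 gives > 10000 nM as a limit too. Compound 3 also gives only a limit, > 10000 nM in the same read-out, so it has no exact number of its own. Within the data shown here, the series so far therefore comes down to the limit of > 10000 nM in this assay, at which 3 of the 3 values shown sit, and nothing finer.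

Compound 4 (`COc1ccc([C@H]2CC(=O)N(c3ccncc3)C2)cc1OC1CCCC1`) has not yet been measured. It has pyridin-4-yl in place of 4-(trifluoromethyl)phenyl on an amide-type nitrogen in a ring, and the counted difference is pyridin-4-yl in place of 4-(trifluoromethyl)phenyl on an amide-type nitrogen in a ring in full. The measured steps that bear on this swap are a step that the two limits leave unreadable from compound 1 to compound 3 and a step that the two limits leave unreadable from compound 2 to compound 3 and also a step that the two limits leave unreadable from compound 1 to compound 2 in the same series. None of them gives a size to carry over, so in this assay no step beyond the scatter is expected and no direction can be named. The expected step is a step that the limit leaves unreadable from compound 3 to compound 4 as an estimate only. For compound 4 the estimate is 15000 nM with 8000 nM to 30000 nM as the expected range, and a report of only a limit is the likeliest outcome.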

Compound 4, half-maximal cytotoxic concentration: > 10000 nM
Compound 4: a limit, no number; the forecaster's own chance of this, stated with the estimate: 90%; the middle value does not contradict the limit.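

No step can be read between compound 4 and compound 1, compound 2 or compound 3, because all four compounds give only a limit and no number: the limit of > 10000 nM in this assay, at which 4 of the 4 values shown sit. The compounds shown leave open the concentration at which any of them harms the cells in this assay, and whether the group on the amide-type nitrogen makes any difference to it.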